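This account rests on a few compounds, and the source may have more. Where it says the series, first, only, none or still open, it means among the compounds named here.

In a functional assay on CCRF-CEM cells (Homo sapiens) for antiproliferative activity, with a stated time of 72 h (on this read-out higher numbers stand for weaker inhibition and lower numbers for stronger inhibition), the measured compounds stand as follows.
Compound 1, `OC[C@H]1O[C@@H](n2cnc3c(NCc4ccccc4Cl)ncnc32)[C@H](O)[C@@H]1O`, gives 14500 nM.
Compound 2, `OC[C@H]1O[C@@H](n2cnc3c(NCc4cccc(Br)c4)ncnc32)[C@H](O)[C@@H]1O`, gives 5000 nM.
Compound 3, `Cc1ccc(CNc2ncnc3c2ncn3[C@@H]2O[C@H](CO)[C@@H](O)[C@H]2O)cc1`, reaches only the limit of > 166000 nM in this assay.

Compound 2 holds the lowest of the two numbers; its nearest neighbour is compound 1, with a 2.9-fold lower number from compound 1 to compound 2 (0.46 log units; beyond the scatter). The compound still to be measured, compound 4, `COc1cc(CNc2ncnc3c2ncn3[C@@H]2O[C@H](CO)[C@@H](O)[C@H]2O)cc(OC)c1`, differs from compound 2 in a single place: 3,5-dimethoxyphenyl in place of 3-bromophenyl on a saturated chain carbon bound to a nitrogen on an aromatic ring. Among the measured compounds shown here, three measured steps bear on this change, all at the same place. The step of a 2.9-fold lower number from compound 1 to compound 2 (0.46 log units; beyond the scatter) shows that exchanging one halogenated ring for another shifts the number only modestly, whereas an at least 11-fold higher number from compound 1 to compound 3 (1.05 log units; beyond the scatter) and an at least 33-fold higher number from compound 2 to compound 3 (1.52 log units; beyond the scatter) show that a 4-methylphenyl at this place pushes the number out to the limit of > 166000 nM in this assay, at which 1 of the 3 values shown sits. For the measured compounds named here, a 3,5-dimethoxyphenyl has not been tested at this place, so the measured steps give no direct guide; the one step within the halogenated rings is modest, and the steps to compound 3 are large and point to a higher number. Compound 4 is therefore expected to sit at a higher number than compound 2, beyond the scatter, though not necessarily at the limit. The expected step in this assay is an 8.0-fold higher number from compound 2 to compound 4 (0.90 log units; beyond the scatter). Compound 4 is estimated at 40000 nM, with a range from 8000 nM to 200000 nM.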

Compound 4, half-maximal inhibitory concentration: > 166000 nM
Compound 4: only a limit was reported; the forecaster's own chance of this, stated with the estimate: 35%; middle value at least 4.1-fold (0.61 log units) away from the limit.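

In this assay, the 3,5-dimethoxyphenyl on this saturated chain carbon bound to a nitrogen on an aromatic ring gives a limit rather than a number, so compound 3 no longer stands alone in that respect: the limit of > 166000 nM in this assay, at which 2 of the 4 values shown sit.

Against the two halogenated rings the change is large, with an at least 33-fold higher number from compound 2 to compound 4 (1.52 log units; beyond the scatter) and an at least 11-fold higher number from compound 1 to compound 4 (1.05 log units; beyond the scatter). Among the four compounds shown, only the 2-chlorophenyl of compound 1 and the 3-bromophenyl of compound 2 give a number, and neither ring without a halogen does, while the step between compound 3 and compound 4 cannot be read, as both values are limits.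

Going by these compounds, what a plain phenyl, a ring with a single methoxy group, or a ring bearing an amine or a carboxylic acid would give at this place stays open. Also open, on these data alone, is whether the kind of halogen or its place on the ring accounts for the gap between compound 1 and compound 2, as these two compounds differ in both.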